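Swapping the Hydroxypyridine Amide for a Methoxyphenyl Amide

A few compounds are considered here, and "the series" means these few. Any claim that something is new, unique, unknown or untested is made for them only; others in the source may bear on it.

Three amides built on the shared core have been measured in an assay on CHO cells for positive allosteric modulation of metabotropic glutamate receptor 5 (Homo sapiens), read by FLIPR; on this read-out higher numbers stand for an effect only at larger amounts of compound and lower numbers for an effect already at smaller amounts. Compound 3 `O=C(Nc1ccc(Cl)cc1CN1C(=O)c2ccccc2C1=O)c1ncccc1O` gives 260 nM, the lowest of the two numbers reported; the nearest is compound 1 `COc1cccc(C(=O)Nc2ccc(Cl)cc2CN2C(=O)c3ccccc3C2=O)c1`, which gives 1500 nM. Compound 2 `O=C(Nc1ccc(Cl)cc1CN1C(=O)c2ccccc2C1=O)c1ccccc1` gives only a limit of the assay, > 100000 nM. That limit is the one at which a single value sits (the limit of > 100000 nM in this assay, at which 1 of the 3 values shown sits).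

Compound 4 `COc1ccccc1C(=O)Nc1ccc(Cl)cc1CN1C(=O)c2ccccc2C1=O` has not yet been measured. It differs from compound 3 in one place: 2-methoxyphenyl in place of 3-hydroxypyridin-2-yl on a carbonyl carbon. Within the data shown here, two measured steps bear on this. The step of a 5.8-fold lower number from compound 1 to compound 3 (0.76 log units; beyond the scatter) shows what the hydroxypyridinyl gained over a methoxyphenyl, and the steps of an at least 66-fold higher number from compound 1 to compound 2 (1.82 log units; beyond the scatter) and an at least 380-fold lower number from compound 2 to compound 3 (2.58 log units; beyond the scatter) show how much rests on having a methoxy or hydroxy group at all. Compound 4 keeps a methoxy, but the group sits in a different place on the ring than in compound 1, so the reverse of the modest step is only a loose guide.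

Compound 4 is therefore expected to show a higher number than compound 3, by about a 12-fold higher number from compound 3 to compound 4 (1.06 log units; beyond the scatter). The estimate for compound 4 in this assay is 3000 nM, with a range from 400 nM to 30000 nM.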

Compound 4, half-maximal effective concentration: > 100000 nM
Compound 4: no number, only a limit; the forecaster's own chance of this, stated with the estimate: 15%; at least 33-fold (1.52 log units) between middle value and limit.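

In this assay compound 4 gives only a limit of the assay, as compound 2 does: the limit of > 100000 nM in this assay, at which 2 of the 4 values shown sit. Putting 2-methoxyphenyl in place of 3-methoxyphenyl on the carbonyl carbon brings an at least 66-fold higher number from compound 1 to compound 4 (1.82 log units; beyond the scatter), so carrying a methoxy is not enough on its own, and where it stands on the ring matters in this pair. Putting 2-methoxyphenyl in place of 3-hydroxypyridin-2-yl brings an at least 380-fold higher number from compound 3 to compound 4 (2.58 log units; beyond the scatter), a step far larger than the modest one that separates compound 1 from compound 3, while the step between compound 2 and compound 4 cannot be read, both values being limits.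

The compounds shown leave open whether what compound 3 holds over the others lies with its ring nitrogen or with its hydroxy, as the two enter together in that group. They also do not tell how a hydroxyphenyl group, an aminophenyl group or an ethoxy in place of the methoxy would read on this carbonyl carbon.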